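The compounds below may be only part of what the source reports. "The series", "measured", "known", "first", "only" and "open" are said of these compounds alone.

In a functional assay on cells (Lymphocyte, Homo sapiens) (a lower number here means a stronger inhibitor, a higher number a weaker inhibitor), compound 1 `Nc1nc(N2CCN(C(=O)COc3ccc(Cl)cc3)CC2)c2nc(-c3ccc(F)cc3)sc2n1` gives 490 nM. Compound 2 `CC(C)(Oc1ccc(Cl)cc1)C(=O)N1CCN(c2nc(N)nc3sc(-c4ccc(F)cc4)nc23)CC1` stands at the limit of the assay, reported as > 10000 nM (the limit of > 10000 nM in this assay, at which 1 of the 2 values shown sits). The step of an at least 20-fold higher number from compound 1 to compound 2 (1.30 log units; beyond the scatter), in which a group of 11 heavy atoms took the place of one of 9 heavy atoms on a carbonyl carbon, was large. Compound 3 `Cc1cccc(NC(=O)N2CCN(c3nc(N)nc4sc(-c5ccc(F)cc5)nc34)CC2)c1` differs from compound 2 by a group of 8 heavy atoms (7 carbon, 1 nitrogen; one six-membered aromatic ring of carbon only) in place of a group of 11 heavy atoms (9 carbon, 1 oxygen, 1 chlorine; one six-membered aromatic ring of carbon only), on a carbonyl carbon. For the measured compounds named here, no measured step matches this exact swap; since compound 2 sits at the limit, the expected step of an at least 5.0-fold lower number from compound 2 to compound 3 (0.69 log units; beyond the scatter) is a gain, but an uncertain one. Compound 3 is estimated at 2000 nM, between 500 nM and 10000 nM.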

Compound 3, half-maximal inhibitory concentration: 300 nM
Compound 3: the middle estimate sits 6.7-fold (0.82 log units) above what was measured; measured number outside the range, below it.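

Compound 2 is a limit of the assay, not a number: the limit of > 10000 nM in this assay, at which 1 of the 3 values shown sits. Even so, an at least 33-fold lower number from compound 2 to compound 3 (1.52 log units; beyond the scatter) shows that the loss seen with compound 2 does not belong to this carbonyl carbon as such, since a group with a carbon ring can work there. With a 1.6-fold lower number from compound 1 to compound 3 (0.21 log units; within the scatter), (3-methylphenyl)amino and (4-chlorophenoxy)methyl cannot be told apart in this assay. On these data alone, it stays open whether the methyl of compound 3 matters, which plain phenylamino would test, and whether dimethylamino, which has no ring, would be accepted on the carbonyl carbon.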